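Replacing a Chlorophenyl Tail with a Phenoxymethyl Linker

The source may hold more compounds than are shown below. What is called first, only, known or untested is meant among the compounds shown, and "the series" means these compounds.

Two compounds sharing one core have been run in an ADME assay (liver) for metabolic stability, with Liver microsome (Rattus norvegicus) as the target, read by LC-MS, using microsomes and NADPH, with stated times of 5 min and 60 min, tested at 4 uM; a higher number here means that more of the compound is left, a lower number that less of the compound is left. Compound 1 `Cc1c(OCCCCOc2ccc(C(=O)O)cc2Cl)ccc(C(=O)CC2CCCC2)c1O` gives 21% in this assay, the higher of the two numbers in hand. Compound 2 `COc1ccc(C(=O)O)cc1OCCCCOc1ccc(C(=O)CC(C)C)c(O)c1C` gives 5% in this assay, a number lower than that of compound 1 by a gap beyond the usual scatter. Among the measured compounds shown here, compounds 1 and 2 differ in more than one place, so no single step is counted between them; their two values show only that compound 1 sits higher.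

Compound 3 `Cc1c(OCCCCOCOc2ccc(C(=O)O)cc2)ccc(C(=O)CC2CCCC2)c1O` is the next member, not yet measured in this assay. It differs from compound 1 in one place: (4-carboxyphenoxy)methyl in place of 4-carboxy-2-chlorophenyl on an oxygen on a saturated carbon

Because compound 1 gives 21% and the other known value of compound 2 lies lower, the author expects a step from compound 1 to compound 3 that is modest and downward, of about a number 8 percentage points lower from compound 1 to compound 3 (within the scatter), though a result within the scatter would not surprise. Compound 3 is accordingly estimated at 13% in this assay, with a range from 3% to 30%.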

Compound 3, percent of the compound remaining: 31%
Beside the measured number, compound 3's estimate is 18 percentage points below it; the whole stated range lies below it.
By their numbers in this assay, from the lowest: compound 2; then compounds 1 and 3 (each within the scatter of the next).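

Among the compounds shown here, the pair of compound 1 and compound 3 is the first in this set to differ in one place, so this assay can now be read for a single exchange: (4-carboxyphenoxy)methyl in place of 4-carboxy-2-chlorophenyl on an oxygen on a saturated carbon gives a number 10 percentage points higher from compound 1 to compound 3 (within the scatter) for this position. With this exchange the chlorine leaves and the carboxylated ring is attached through a phenoxymethyl link, yet compound 1 at 21% and compound 3 at 31% remain within the scatter of each other. The position therefore accepts two quite different carboxylated tails with no difference that this read-out can resolve.

Since the chlorine and the link are exchanged together, the step cannot be divided between them, and the compounds shown do not tell how a plain 4-carboxyphenyl, or an amide in place of the carboxylic acid, would read at this place. No measurement at hand bears on why the step reads as it does.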